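The source may report more compounds than this note shows. Statements on the series, on what has been measured and on what is new or still open speak of the compounds shown alone.

Of the compounds shown here, three sharing one core have been measured in an assay on isolated protein for inhibition of protein kinase C delta type (Homo sapiens), read by TR-FRET, with a stated time of 2 h; a higher number here means a weaker inhibitor, a lower number a stronger inhibitor. Compound 1 `N#Cc1cnc(NCc2cnccc2C(F)(F)F)cc1N[C@H]1CC[C@@H](O)CC1` gives 4500 nM in this assay. Compound 2 `N#Cc1cnc(NCc2cnccc2C(F)(F)F)cc1N[C@H]1CC[C@@H](n2cncn2)CC1` gives 5500 nM in this assay. Compound 3 `CC(C)(C)Oc1ncncc1CNc1cc(N[C@H]2CC[C@@H](O)CC2)c(C#N)cn1` gives 200 nM in this assay. Among the compounds with values here, the only measured step that changes a single place is a 1.2-fold higher number from compound 1 to compound 2 (0.09 log units; within the scatter), so exchanging the hydroxy for the triazole on the saturated ring leaves the number essentially where it was. Compound 1 therefore holds the second highest of the three numbers: compound 2 stands closest, within the scatter, and compound 3 stands furthest, with a clearly lower number, but compound 3 differs from compound 1 in more than one place, so no single step can be read from that pair.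

Compound 4 `CC1(C)C[C@@H](Nc2cc(NCc3cnccc3C(F)(F)F)ncc2C#N)CC[C@@H]1O` has not yet been measured. It differs from compound 1 in one place: 4-hydroxy-3,3-dimethylcyclohexyl in place of 4-hydroxycyclohexyl on a nitrogen on an aromatic ring. Within the data shown here, no measured step covers an addition of this kind to the saturated ring; the one step that does alter that ring, from compound 1 to compound 2, was within the scatter. On that slender basis, compound 4 is expected to sit close to compound 1, with a step of a 1.3-fold lower number from compound 1 to compound 4 (0.11 log units; within the scatter), and the estimate for compound 4 in this assay is 3500 nM, ranging from 1200 nM to 10000 nM.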

Compound 4, half-maximal inhibitory concentration: 2400 nM
Estimate against measurement, compound 4: 1.5-fold (0.16 log units) above, within the range that was stated.
By their numbers in this assay, from the lowest: compound 3; then compounds 4, 1 and 2 (each within the scatter of the next, the first and the last beyond it).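

In this assay, putting 4-hydroxy-3,3-dimethylcyclohexyl in place of 4-hydroxycyclohexyl on the nitrogen gives a 1.9-fold lower number from compound 1 to compound 4 (0.27 log units; within the scatter), so this change cannot be told apart from ordinary repeat variation. The earlier step at this ring exchanged the hydroxy itself for a triazole, whereas this one keeps the hydroxy and adds the two methyl groups to the saturated ring, and neither kind of change moves the number beyond the scatter in these compounds. Nothing at hand explains this result or shows what the two methyl groups do.

From the compounds shown here alone, it remains open whether a single methyl, a larger group such as ethyl on the same ring carbon, or an amine or a carboxylic acid in place of the hydroxy would move the number beyond the scatter. Going by these compounds, it is also open whether the 4-hydroxy-3,3-dimethylcyclohexyl group would behave the same way on compound 3, which gives 200 nM and carries a different group on the far side of the shared core.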